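The source may hold more compounds than are shown below. What is called first, only, known or untested is meant among the compounds shown, and "the series" means these compounds.

Working notes on the series. Compound 3 `CCn1c(=O)n(C2OC(CO)[C@@H](O)[C@H]2O)c2nc(N)nc(O)c21` carries a methyl on a saturated chain carbon bound to an aromatic nitrogen; in a functional assay on the whole organism with Mus musculus as the target (a lower number here means a smaller maximal response, a higher number a larger maximal response), compound 3 gives 82%, the highest of the three measured numbers, and both gaps to the other two lie beyond the scatter. Compound 1 `COc1ccc(Cn2c(=O)n(C3OC(CO)[C@@H](O)[C@H]3O)c3nc(N)nc(O)c32)cc1` carries 4-methoxyphenyl at that place, and in this assay compound 1 gives 14%. Compound 2 `CCCCCCn1c(=O)n(C2OC(CO)[C@@H](O)[C@H]2O)c2nc(N)nc(O)c21` carries pentyl there, and in this assay compound 2 gives 11%. The two measured steps that reach compound 3 are both large: a number 68 percentage points higher from compound 1 to compound 3 (beyond the scatter) and a number 71 percentage points higher from compound 2 to compound 3 (beyond the scatter). The remaining step is small, a number 3 percentage points lower from compound 1 to compound 2 (within the scatter).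

Compound 4 `Nc1nc(O)c2c(n1)n(C1OC(CO)[C@@H](O)[C@H]1O)c(=O)n2Cc1ccc([N+](=O)[O-])cc1` is not yet measured. The change is 4-nitrophenyl in place of methyl on a saturated chain carbon bound to an aromatic nitrogen. It runs against the two steps into compound 3: a larger group again replaces methyl at the same place, and in compound 1 a six-membered aromatic ring of carbon only at that place went with a small maximal response. The bearing steps are the two large ones, so a large downward step in this assay is expected, of about the size seen with 4-methoxyphenyl. The expected step is a number 67 percentage points lower from compound 3 to compound 4 (beyond the scatter). Compound 4 is therefore expected to give 15% in this assay, with a range from 5% to 35%.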

Compound 4, largest response reached (reported as maximal response), in percent of the reference or control that the assay uses: 16%
Beside the measured number, compound 4's estimate is 1 percentage points below it; the range from low to high includes it.
By their numbers in this assay, from the lowest: compounds 2, 1 and 4 (each within the scatter of the next); then compound 3.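

In this assay, among these compounds, 4-nitrophenyl in place of methyl gives a large step (a number 66 percentage points lower from compound 3 to compound 4 (beyond the scatter)), and nitro in place of methoxy on an aromatic carbon stays within the scatter (a number 2 percentage points higher from compound 1 to compound 4 (within the scatter)), so the small maximal response seen with the aromatic ring at this place is not confined to the methoxy compound. 4-Nitrophenyl in place of pentyl is also within the scatter (a number 5 percentage points higher from compound 2 to compound 4 (within the scatter)), which places the aromatic and chain groups of compounds 1, 2 and 4 at one level, with the methyl of compound 3 as the only group standing apart from them. Nothing at hand bears on what lies behind this split between methyl and the larger groups.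

The compounds shown leave open where between methyl and pentyl the large maximal response is lost, which ethyl or propyl on the saturated chain carbon could help to place. They also leave open whether a carboxylic acid or an amine on the aromatic ring would stay at the level of compounds 1 and 4.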